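Dropping a Trifluoromethyl from the Amide Tail

The source may hold more compounds than are shown below. What is called first, only, known or untested is meant among the compounds shown, and "the series" means these compounds.

Two compounds have been measured in a functional assay on COLO 205 cells (Homo sapiens) for inhibition, read by sulforhodamine B assay, with a stated time of 48 h; a higher number here means a weaker inhibitor of growth, a lower number a stronger inhibitor of growth:

Compound 1, `COc1cc(-c2nn(-c3cccc(NC(=O)c4cccc(C(F)(F)F)c4)c3)cc2-c2ccncc2)ccc1Cl`, gives 1640 nM.
Compound 2, `O=C(Nc1cccc(-n2cc(-c3ccncc3)c(-c3ccc(Cl)c(O)c3)n2)c1)Nc1cc(C(F)(F)F)cc(C(F)(F)F)c1`, gives 853 nM.

Compound 1 has the higher of the two numbers, but compound 2 sits close to it, and the gap between them lies within the usual scatter of this assay, so neither can be called the stronger inhibitor of growth.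

The step considered here leads from compound 1 to compound 3, `COc1cc(-c2nn(-c3cccc(NC(=O)c4ccccc4)c3)cc2-c2ccncc2)ccc1Cl`, which has not yet been measured. The change is small and confined to the outer benzoyl part of the molecule: hydrogen in place of trifluoromethyl on an aromatic carbon. The shared core and everything else stay untouched.

Among the compounds with values here, no measured pair in this set shows what such a change does, so the expectation rests on the change alone. Loss of a group of four heavy atoms at the far end of the amide is expected to cost some potency, and the step from compound 1 to compound 3 is estimated as a 3.0-fold higher number from compound 1 to compound 3 (0.48 log units; beyond the scatter), toward a higher number. Compound 3 is therefore expected to give about 5000 nM in this assay, with a likely range from 1500 nM to 15000 nM.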

Compound 3, concentration for 50% growth inhibition: 522 nM
The estimate for compound 3 lay 9.6-fold (0.98 log units) above the measured number, and the stated range ends above it.
By their numbers in this assay, from the lowest: compounds 3, 2 and 1 (each within the scatter of the next, the first and the last beyond it).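

Taking the trifluoromethyl off the outer benzoyl part does not weaken growth inhibition in this assay; the step is a 3.1-fold lower number from compound 1 to compound 3 (0.50 log units; beyond the scatter), so in this pair the unsubstituted benzoyl outperforms the (3-(trifluoromethyl)phenyl)carbonyl group, and those four heavy atoms are not needed for activity. Within the data shown here, compound 1 and compound 2 differ in more than one place, so together they could not isolate the contribution of this position, whereas this single change does so for the first time. Nothing available here explains why the lower number follows the loss of the group.

Among these compounds, this is one swap at one position, with hydrogen and trifluoromethyl as the only two groups compared, so it remains open whether a group such as methyl, chlorine, methoxy, an amine or a carboxylic acid at the same carbon would give a lower or a higher number than hydrogen. On these data alone, it also remains open whether the same change would have a similar effect in another setting, such as on the trifluoromethyl groups of the urea tail of compound 2.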